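Benzyl for Cyclohexyl on a Second Benzimidazole Core

The compounds below may be only part of what the source reports. "The series", "measured", "known", "first", "only" and "open" are said of these compounds alone.

Compound 1 `c1ccc2c(-c3cn4ccnc4c(-c4ccc5ncn(C6CCCCC6)c5c4)n3)cccc2c1` gives 36.5% in a functional assay on PC-3 cells (Homo sapiens) for inhibition, read by sulforhodamine B assay, with a stated time of 48 h, tested at 10 uM; a lower number here means less inhibition, a higher number more inhibition at the concentration tested (going by the name of the read-out). Compound 2 `c1ccc(Cn2cnc3ccc(-c4nc(-c5cccc6ccccc56)cn5ccnc45)cc32)cc1` gives 31.4% in this assay; the change benzyl in place of cyclohexyl on an aromatic nitrogen made a step of a number 5.1 percentage points lower from compound 1 to compound 2 (within the scatter). Compound 3 `c1cn2cc(-c3ccc4c(c3)ncn4C3CCCCC3)nc(-c3ccc4ncn(C5CCCCC5)c4c3)c2n1` gives 45% in this assay; the difference between its core and that of compound 1 is not broken down here. Compound 4 `c1ccc(Cn2cnc3ccc(-c4nc(-c5ccc6c(c5)ncn6C5CCCCC5)cn5ccnc45)cc32)cc1` has not been measured; it differs from compound 3 by benzyl in place of cyclohexyl on an aromatic nitrogen, the same kind of change as from compound 1 to compound 2. The expectation rests on that earlier step being within the scatter, so compound 4 is estimated to give 40%, between 28% and 52%, a step of a number 5 percentage points lower from compound 3 to compound 4 (within the scatter) that is expected to remain within the scatter.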

Compound 4, a percentage reported as inhibition, at one concentration (the size of the read-out at that concentration, not a potency): -39.5%
The estimate for compound 4 lay 79.5 percentage points above the measured number; the measured number lies below the stated range.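

In this assay, benzyl in place of cyclohexyl on an aromatic nitrogen gave a number 84.5 percentage points lower from compound 3 to compound 4 (beyond the scatter). The change therefore did not carry over from one core to the other at the same size: the same change on two cores in this assay, a number 5.1 percentage points lower (within the scatter) from compound 1 to compound 2 and a number 84.5 percentage points lower (beyond the scatter) from compound 3 to compound 4, 79.4 percentage points apart, beyond the scatter of two such steps. This shows that, across these two pairs, the size of the step differs with the core, but it does not show which feature of the core is responsible or how the change would behave on any further core.

The compounds shown leave open what other groups on that aromatic nitrogen would give, such as a longer alkyl chain or a chain ending in an amine. They also leave open whether a carboxylic acid on the benzyl ring would alter the step.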